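Chloro in Place of Hydrogen on a Chalcone-Derived Scaffold

The compounds below may be only part of what the source reports. "The series", "measured", "known", "first", "only" and "open" are said of these compounds alone.

Measured compounds:
compound 1 `COc1cc(Br)cc(/C=C/C(=O)c2ccccc2)c1O`: 28.1%
compound 2 `COC(=O)C1=C(N)Oc2c(OC)cc(Br)cc2C1CC(=O)c1ccc(Cl)cc1`: 33.8%
compound 3 `COc1cc(Br)cc2c1OC(N)=C(C#N)C2CC(=O)c1ccccc1`: 36.7%

Of the compounds shown here, three have been measured in a functional assay on MCF7 cells (Homo sapiens) for antiproliferative activity, read by sulforhodamine B assay, with a stated time of 72 h, tested at 30 uM; on this read-out lower numbers stand for a stronger effect and higher numbers for a weaker effect at the one concentration tested. Compound 1 gives 28.1%, compound 2 gives 33.8%, and compound 3 gives 36.7%. On these numbers compound 3 stands highest of the three, but its nearest neighbour, compound 2, sits only within the scatter below it, and even compound 1, the furthest, lies within the scatter as well. For the measured compounds named here, no two of the measured compounds differ in a single place, so no step between them can be read off.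

The unmeasured compound 4 `COc1cc(Br)cc2c1OC(N)=C(C#N)C2CC(=O)c1ccc(Cl)cc1` differs from compound 3 by chloro in place of hydrogen on an aromatic carbon. The change sits on an aromatic carbon of a six-membered aromatic ring of carbon only, para to a large group; cut one bond further out, it reads phenyl to 4-chlorophenyl. Compound 2 also carries the chloro group and gives a number within the scatter of compound 3, but it differs from compound 3 in more than one place, so it cannot settle the step. No step beyond the scatter is expected in this assay; the step of a number 2.7 percentage points lower from compound 3 to compound 4 (within the scatter) is an estimate. Compound 4 is expected to give 34%, within a range from 22% to 46%.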

Compound 4, a percentage reported as activity, at one concentration (the size of the read-out at that concentration, not a potency): 33.3%
Compound 4: middle estimate off by 0.7 percentage points, on the high side, within the range that was stated.
By their numbers in this assay, from the lowest: compounds 1, 4, 2 and 3 (each within the scatter of the next).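

For the compounds shown here, the new compound gives the first clean reading of this position. In this assay, chloro in place of hydrogen on an aromatic carbon, para to a large group, amounts to a step (a number 3.4 percentage points lower from compound 3 to compound 4 (within the scatter)), so phenyl to 4-chlorophenyl on this scaffold does not move the read-out beyond the usual scatter. Compound 4 also makes a second change readable on its own, cyano in place of methoxycarbonyl on a double-bonded ring carbon with the 4-chlorophenyl kept, and that step (a number 0.5 percentage points lower from compound 2 to compound 4 (within the scatter)) stays within the scatter too. Nothing measured beyond these percentages bears on this result.

Each change is read only once, on a single background and at a single concentration, so these steps say nothing about potency or about whether they would hold on another background. It remains open whether a fluoro, an amine or a carboxylic acid on that same aromatic carbon, or a carboxylic acid or an amide on the double-bonded ring carbon, would give a number outside the scatter of these compounds.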